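Compound 4 tests a side-chain change on the core of compound 1

This account rests on a few compounds, and the source may have more. Where it says the series, first, only, none or still open, it means among the compounds named here.

Compound 1 `CC(C)C[C@H](N)c1cc(C(F)(F)F)ccc1N1CCN(C(=O)CC(C)C(=O)c2ccc(Cl)cc2)CC1` is the anchor of this small set. In an assay on HEK293 cells for displacement of a labelled ligand from Melanocortin receptor 4 (Homo sapiens) (on this read-out higher numbers stand for weaker inhibition and lower numbers for stronger inhibition), compound 1 gives 1100 nM, the lowest number of the three measured. Compound 2 `CC(C)C[C@H](N)c1cc(C(F)(F)F)ccc1N1CCN(C(=O)CCNC2CCCCC2)CC1` gives 4800 nM and compound 3 `Cc1ccc(OCC(=O)N2CCN(c3ccc(C(F)(F)F)cc3[C@@H](N)CC(C)C)CC2)c(C)c1` gives 4000 nM in this assay, so that a 4.4-fold higher number from compound 1 to compound 2 (0.64 log units; beyond the scatter) and a 3.6-fold higher number from compound 1 to compound 3 (0.56 log units; beyond the scatter), while a 1.2-fold lower number from compound 2 to compound 3 (0.08 log units; within the scatter).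

Compound 4 `Cc1cc(Cl)ccc1CC(C)C(=O)N1CCN(c2ccc(C(F)(F)F)cc2[C@@H](N)CC(C)C)CC1` differs from compound 1 at the carbonyl carbon: 1-(4-chloro-2-methylbenzyl)ethyl in place of 2-((4-chlorophenyl)carbonyl)propyl on a carbonyl carbon. Both earlier steps away from the side chain of compound 1 weakened binding modestly, but compound 4 keeps an aromatic ring with chlorine, unlike compound 2 or compound 3. A small loss, or none beyond the scatter, is therefore expected, a 1.6-fold higher number from compound 1 to compound 4 (0.21 log units; within the scatter). Compound 4 is estimated at 1800 nM, within 700 nM to 4500 nM.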

Compound 4, inhibition constant: 38 nM
Compound 4: middle estimate off by 47-fold (1.68 log units), on the high side; measured number outside the range, below it.
By their numbers in this assay, from the lowest: compound 4; then compound 1; then compounds 3 and 2 (each within the scatter of the next).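

At this position, on the carbonyl carbon, the side chain can move binding far more than compounds 2 and 3 suggested: 1-(4-chloro-2-methylbenzyl)ethyl in place of 2-((4-chlorophenyl)carbonyl)propyl gives a 29-fold lower number from compound 1 to compound 4 (1.46 log units; beyond the scatter). Against the other two side chains the same group gives a 110-fold lower number from compound 3 to compound 4 (2.02 log units; beyond the scatter) and a 130-fold lower number from compound 2 to compound 4 (2.10 log units; beyond the scatter), so an aromatic side chain alone does not secure this gain. No evidence at hand explains the change.

Still open, on these data alone, is whether the ring methyl or the loss of the chain carbonyl carries the step, and whether an amine or a carboxylic acid on this chain would keep it.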